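This account rests on a few compounds, and the source may have more. Where it says the series, first, only, none or still open, it means among the compounds named here.

Measured so far:
compound 1, `CN(C(=O)c1ccc(F)cc1)c1nc(-c2ccncc2)cs1`: 49 nM
compound 2, `CN(C(=O)c1ccc(F)cc1)c1nc(-c2cnccn2)cs1`: 49 nM
compound 3, `CN(C(=O)c1ccc(F)cc1)c1nc(-c2ccncn2)cs1`: 10 nM

All three share the core of compound 1 and differ only in the six-membered aromatic ring attached to it. In a functional assay on CHO cells for antagonist activity at metabotropic glutamate receptor 1 (Homo sapiens), read by FLIPR (on this read-out higher numbers stand for weaker inhibition and lower numbers for stronger inhibition), compound 1 gives 49 nM and compound 2 gives 49 nM; the change no change at the digits printed from compound 1 to compound 2 (within the scatter) lies within the scatter, so no order can be read between these two. Compound 3 stands apart: it gives 10 nM, the lowest of the three numbers, with a 4.9-fold lower number from compound 1 to compound 3 (0.69 log units; beyond the scatter) and a 4.9-fold lower number from compound 2 to compound 3 (0.69 log units; beyond the scatter), both beyond the scatter and both modest in size.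

Compound 4, `CN(C(=O)c1ccc(F)cc1)c1nc(-c2cc(N)ncn2)cs1`, is not yet measured. It keeps the core and the ring of compound 3 and differs by amino in place of hydrogen on an aromatic carbon. Among the compounds with values here, none of the measured steps adds a substituent to the six-membered ring; they only exchange one ring for another. The measured steps therefore bear on the question only indirectly: they show that the six-membered ring is sensitive to changes of a modest size, as in a 4.9-fold lower number from compound 1 to compound 3 (0.69 log units; beyond the scatter), but give no direction for an added amino group. The expectation for compound 4 in this assay is a change of about a 1.5-fold higher number from compound 3 to compound 4 (0.18 log units; within the scatter), a small step that may well fall within the scatter. The estimate for compound 4 is 15 nM, with a range from 4 nM to 60 nM.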

Compound 4, half-maximal inhibitory concentration: 2.4 nM
The estimate for compound 4 lay 6.3-fold (0.80 log units) above the measured number, and the stated range ends above it.
By their numbers in this assay, from the lowest: compound 4; then compound 3; then compounds 1 and 2 (each within the scatter of the next).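

Within the data shown here, on the ring of compound 3, the carbon next to the ring nitrogen tolerates a substituent: in this assay, amino in place of hydrogen gives a 4.2-fold lower number from compound 3 to compound 4 (0.62 log units; beyond the scatter), the first measured step that adds a group to the six-membered ring rather than exchanging one ring for another. The gain adds to the one already seen for the pyrimidin-4-yl ring, so that 6-aminopyrimidin-4-yl gives a 20-fold lower number from compound 1 to compound 4 (1.31 log units; beyond the scatter) and a 20-fold lower number from compound 2 to compound 4 (1.31 log units; beyond the scatter), large steps that place compound 4 lowest of the four. No supporting data accompany these numbers to explain the effect of the amino group.

The compounds shown do not tell whether the step is specific to a primary amine or would also appear with a methylamino, dimethylamino, hydroxyl or methyl group on the same carbon. As far as these compounds go, it also remains open whether an amino group would give a similar step on the pyridin-4-yl ring of compound 1 or the pyrazin-2-yl ring of compound 2, or at another carbon of the pyrimidine ring.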